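The source may report more compounds than this note shows. Statements on the series, on what has been measured and on what is new or still open speak of the compounds shown alone.

Of the compounds shown here, three that share one core have been measured in an assay on HEK293 cells for binding affinity to Gonadotropin-releasing hormone receptor (Homo sapiens), read by radioligand binding; on this read-out lower numbers stand for stronger inhibition and higher numbers for weaker inhibition. Compound 1 `COc1cccc(-c2c(C)n(Cc3c(F)cccc3F)c(=O)n(C[C@@H](N)C3CCCC3)c2=O)c1F` gives 94 nM. Compound 2 `COc1cccc(-c2c(C)n(Cc3c(F)cccc3F)c(=O)n(C[C@@H](N)CCc3ccccc3)c2=O)c1F` gives 965 nM, the highest of the three numbers; its nearest neighbour is compound 1, at a 10-fold higher number from compound 1 to compound 2 (1.01 log units; beyond the scatter), and the furthest is compound 3 `COc1cccc(-c2c(C)n(Cc3c(F)cccc3F)c(=O)n(C[C@H](N)CC(C)C)c2=O)c1F`, which gives 6.4 nM and lies at a 150-fold lower number from compound 2 to compound 3 (2.18 log units; beyond the scatter). Between compound 1 and compound 3 the step is a 15-fold lower number from compound 1 to compound 3 (1.17 log units; beyond the scatter).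

Compound 4 `COc1cccc(-c2c(C)n(Cc3c(F)cccc3F)c(=O)n(C[C@H](NC(C)C)C3CCCC3)c2=O)c1F` has not yet been measured. It differs from compound 2 in one place: cyclopentyl(isopropylamino)methyl in place of 1-amino-3-phenylpropyl on a saturated chain carbon bound to an aromatic nitrogen. Part of this change, cyclopentyl returning in place of phenethyl, is the reverse of the step of a 10-fold higher number from compound 1 to compound 2 (1.01 log units; beyond the scatter), a large one, so that part alone would be expected to bring the number well down toward that of compound 1. Among the compounds with values here, the other part, an isopropyl group on the amine nitrogen, has no counterpart among the measured steps; nothing here shows what it does. The expectation therefore rests on compound 1 with a wide margin. Compound 4 is expected to come in near 60 nM, within a range of 10 nM to 400 nM. The step this estimate implies is a 16-fold lower number from compound 2 to compound 4 (1.21 log units; beyond the scatter).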

Compound 4, inhibition constant: 12 nM
For compound 4 the middle estimate is 5.0-fold (0.70 log units) above the measured one, within the range that was stated.
By their numbers in this assay, from the lowest: compounds 3 and 4 (each within the scatter of the next); then compound 1; then compound 2.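

In this assay, a cyclopentyl group in this place can go with a low number, which compound 1 had not shown: the change from 1-amino-3-phenylpropyl to cyclopentyl(isopropylamino)methyl gives a large drop (an 80-fold lower number from compound 2 to compound 4 (1.91 log units; beyond the scatter)). Compared with amino(cyclopentyl)methyl, the new group also lowers the number (a 7.8-fold lower number from compound 1 to compound 4 (0.89 log units; beyond the scatter)), but this step adds an isopropyl group on the amine nitrogen and, as the structures are drawn, also reverses the hand of the stereocentre, so the two changes cannot be told apart. The cyclopentyl compound with the isopropyl group cannot be separated from the 1-amino-3-methylbutyl compound (a 1.9-fold higher number from compound 3 to compound 4 (0.27 log units; within the scatter)), and nothing at hand explains any of these differences.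

The compounds shown leave open how much of the drop belongs to the isopropyl group and how much to the hand of the stereocentre, since no pair here changes only one of the two. They also leave open whether a smaller group on the amine nitrogen, such as methyl or ethyl, or a larger one, such as cyclohexyl, would give a similar number.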